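Swapping the ring partner: from thiophene to pyridine

The source may report more compounds than this note shows. Statements on the series, on what has been measured and on what is new or still open speak of the compounds shown alone.

Among the measured compounds shown here, compound 2 `Cc1c(NC2=NCCN2)cccc1-c1cccs1` gives the lowest of the two numbers so far in an assay for binding affinity to Adrenergic receptor alpha-1 (Rattus norvegicus) (a lower number here means a stronger inhibitor, a higher number a weaker inhibitor), at 102 nM. Its nearest neighbour, compound 1 `Cc1c(NC2=NCCN2)cccc1-c1ccccc1`, gives 209 nM, and the step of a 2.0-fold lower number from compound 1 to compound 2 (0.31 log units; beyond the scatter) reflects a thiophen-2-yl in place of phenyl. Compound 3 `Cc1c(NC2=NCCN2)cccc1-c1cccnc1` takes the next step: pyridin-3-yl in place of thiophen-2-yl on an aromatic carbon. For the measured compounds named here, no measured step shows a pyridine ring at this position, so the one step available is only a loose guide. Compound 3 is therefore expected to land near the measured pair, with a step of a 1.8-fold higher number from compound 2 to compound 3 (0.25 log units; within the scatter) that is no more than modest. The estimate for compound 3 is 180 nM, between 60 nM and 550 nM.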

Compound 3, inhibition constant: 257 nM
Compound 3: middle estimate off by 1.4-fold (0.15 log units), on the low side, within the range that was stated.
By their numbers in this assay, from the lowest: compound 2; then compounds 1 and 3 (each within the scatter of the next).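

Replacing thiophen-2-yl with pyridin-3-yl gives a 2.5-fold higher number from compound 2 to compound 3 (0.40 log units; beyond the scatter) in this assay and so gives back the gain that thiophen-2-yl showed over phenyl. Among the compounds shown here, measured against phenyl, the same pyridine ring gives a 1.2-fold higher number from compound 1 to compound 3 (0.09 log units; within the scatter) and so no readable change, which leaves thiophen-2-yl as the only one of these three rings that stands apart. Nothing at hand explains this difference. From the compounds shown here alone, whether a furan-2-yl ring would behave like thiophen-2-yl stays open. So does the effect of moving the ring nitrogen, as in pyridin-2-yl or pyridin-4-yl.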